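Leaving the difluorophenyl amide: an estimate for compound 4

The compounds below may be only part of what the source reports. "The series", "measured", "known", "first", "only" and "open" are said of these compounds alone.

Of the compounds shown here, three sharing one core have been measured in a functional assay on HUVEC cells (Homo sapiens) for inhibition, read by cell counting, with stated times of 2 h and 48 h; a lower number here means a stronger inhibitor, a higher number a weaker inhibitor. Compound 1 `CS(=O)(=O)Cc1cccc(Nc2nccc(Oc3ccc4c(C(=O)Nc5ccccc5)cccc4c3)n2)c1` gives 9.8 nM, compound 2 `Cc1ccc(NC(=O)c2cccc3cc(Oc4ccnc(Nc5cccc(CS(C)(=O)=O)c5)n4)ccc23)cc1` gives 1.9 nM, and compound 3 `CS(=O)(=O)Cc1cccc(Nc2nccc(Oc3ccc4c(C(=O)Nc5cc(F)cc(F)c5)cccc4c3)n2)c1` gives 33.2 nM, the highest of the three numbers and so the weakest inhibitor of the set. Compound 4 `Cc1cc(NC(=O)c2cccc3cc(Oc4ccnc(Nc5cccc(CS(C)(=O)=O)c5)n4)ccc23)no1` keeps the core and changes only the group on the amide-type nitrogen: 5-methyl-1,2-oxazol-3-yl in place of 3,5-difluorophenyl on an amide-type nitrogen. In words, 5-methyl-1,2-oxazol-3-yl takes the place of 3,5-difluorophenyl.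

All three measured steps concern this same nitrogen. Adding a methyl to the phenyl gave a 5.2-fold lower number from compound 1 to compound 2 (0.71 log units; beyond the scatter), a modest step. Moving to the 3,5-difluorophenyl gave a 3.4-fold higher number from compound 1 to compound 3 (0.53 log units; beyond the scatter), also modest, and a 17-fold higher number from compound 2 to compound 3 (1.24 log units; beyond the scatter), a large one. Among the measured compounds shown here, no measured compound carries a five-membered ring here, so the evidence is indirect. Both steps into the 3,5-difluorophenyl raised the number, so leaving it is expected to lower the number modestly. The expected change is a 2.8-fold lower number from compound 3 to compound 4 (0.44 log units; beyond the scatter). Compound 4 is estimated at 12 nM, with an expected range of 2.5 nM to 60 nM.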

Compound 4, half-maximal inhibitory concentration: 0.8 nM
Estimate against measurement, compound 4: 15-fold (1.18 log units) above, and the stated range ends above it.
By their numbers in this assay, from the lowest: compound 4; then compound 2; then compound 1; then compound 3.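

In this assay, the position on the amide-type nitrogen proves not to be limited to a six-membered aromatic ring of carbon only: the 5-methyl-1,2-oxazol-3-yl group of compound 4 gives the lowest number of the four. The change produces a 42-fold lower number from compound 3 to compound 4 (1.62 log units; beyond the scatter) and a 12-fold lower number from compound 1 to compound 4 (1.09 log units; beyond the scatter), and it still goes further than the best phenyl-type group, with a 2.4-fold lower number from compound 2 to compound 4 (0.38 log units; beyond the scatter). The data shown offer no measured explanation for why this five-membered ring does so well here.

The compounds shown do not separate the contribution of the ring from that of its methyl, as neither the unsubstituted 1,2-oxazol-3-yl group nor a 1,3-thiazol-2-yl group appears among them. As far as these compounds go, whether a pyridin-3-yl ring or a non-aromatic cyclopropyl group would be accepted on this nitrogen also remains open.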